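Changing the amide aryl group: from compound 2 to compound 3

The compounds below may be only part of what the source reports. "The series", "measured", "known", "first", "only" and "open" are said of these compounds alone.

Measured so far:
compound 1, `COc1ccccc1NC(=O)CCC(=O)OCCCCCCSc1ccc([N+](=O)[O-])c2nonc12`, 1610 nM
compound 2, `O=C(CCC(=O)OCCCCCCSc1ccc([N+](=O)[O-])c2nonc12)Nc1ccc(C(F)(F)F)cc1`, 1390 nM

In an ADME assay on HUVEC cells (Homo sapiens) for cytotoxicity, read by MTT assay, with a stated time of 72 h (on this read-out higher numbers stand for weaker inhibition and lower numbers for stronger inhibition), compound 2 gives 1390 nM, the lowest of the two numbers, with compound 1 the nearest to it. Among the compounds with values here, the one step seen, a 1.2-fold lower number from compound 1 to compound 2 (0.06 log units; within the scatter), changes the same aryl group. Compound 3, `COc1ccc(NC(=O)CCC(=O)OCCCCCCSc2ccc([N+](=O)[O-])c3nonc23)cc1OC`, differs from compound 2 by 3,4-dimethoxyphenyl in place of 4-(trifluoromethyl)phenyl on an amide-type nitrogen. On that single step, a change in this assay of no more than the scatter is expected from compound 2 to compound 3, a 1.1-fold higher number from compound 2 to compound 3 (0.03 log units; within the scatter). Compound 3 is therefore estimated at 1500 nM, within 700 nM to 3200 nM.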

Compound 3, half-maximal inhibitory concentration: 870 nM
Beside the measured number, compound 3's estimate is 1.7-fold (0.24 log units) above it, within the range that was stated.
By their numbers in this assay, from the lowest: compounds 3, 2 and 1 (each within the scatter of the next).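

Placing 3,4-dimethoxyphenyl on the amide-type nitrogen gives a 1.6-fold lower number from compound 2 to compound 3 (0.20 log units; within the scatter) in this assay and a 1.9-fold lower number from compound 1 to compound 3 (0.27 log units; within the scatter) in the same assay, so this third aryl group also stays within the scatter of both earlier compounds. The position has now taken an aryl group with 2 hydrogen-bond acceptors as well as one with 0, with no step beyond the scatter. Nothing measured here bears on what lies behind these numbers. From the compounds shown here alone, whether a non-aromatic group on that nitrogen, such as cyclohexyl, or an aryl group carrying an amine or a carboxylic acid would move the number beyond the scatter remains open.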